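A few compounds are considered here, and "the series" means these few. Any claim that something is new, unique, unknown or untested is made for them only; others in the source may bear on it.

Measured compounds in a functional assay on SW-620 cells (Homo sapiens) for antiproliferative activity, read by MTT assay, with a stated time of 72 h; a higher number here means a weaker inhibitor, a lower number a stronger inhibitor:
Compound 1, `Cc1ccc(S(=O)(=O)NCc2cn(C[C@H](O)[C@H]3OC(=O)C(OCc4ccccc4)=C3OCc3ccccc3)nn2)cc1`, gives 45800 nM.
Compound 2, `O=C1O[C@H]([C@@H](O)Cn2cc(-c3cccc(O)c3)nn2)C(OCc2ccccc2)=C1OCc1ccccc1`, reaches only a limit of the assay, > 100000 nM.
Compound 3, `O=C1O[C@H]([C@@H](O)Cn2cc(CNS(=O)(=O)c3ccc(F)cc3)nn2)C(OCc2ccccc2)=C1OCc1ccccc1`, gives 41100 nM.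

Compound 3 stands at the lowest of the two numbers shown, but compound 1 sits within the scatter of it, as the step of a 1.1-fold lower number from compound 1 to compound 3 (0.05 log units; within the scatter) shows, so the two cannot be told apart. Compound 2 is known only as a limit, (the limit of > 100000 nM in this assay, at which 1 of the 3 values shown sits).

Compound 4, `C[Si](C)(C)c1cn(C[C@H](O)[C@H]2OC(=O)C(OCc3ccccc3)=C2OCc2ccccc2)nn1`, differs from compound 3 in one place: a group of 4 heavy atoms (3 carbon, 1 silicon; no ring) in place of a group of 12 heavy atoms (7 carbon, 1 nitrogen, 2 oxygen, 1 fluorine, 1 sulfur; one six-membered aromatic ring of carbon only), on an aromatic carbon.

Among the measured compounds shown here, no measured step matches this change directly. The nearest evidence is an at least 2.4-fold lower number from compound 2 to compound 3 (0.38 log units; beyond the scatter) and an at least 2.1-fold higher number from compound 1 to compound 2 (0.33 log units; beyond the scatter): in both, the member carrying the sulfonamide-bearing group gives the lower number, while the compound with a plain aromatic substituent falls beyond the limit. Compound 4 also loses the sulfonamide-bearing group, for a group with no hydrogen-bond donors or acceptors. A weaker inhibitor is therefore expected, and compound 4 is estimated at 85000 nM (range 35000 nM to 200000 nM), a step of a 2.1-fold higher number from compound 3 to compound 4 (0.32 log units; beyond the scatter), with a fair chance that only a limit is reported.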

Compound 4, half-maximal inhibitory concentration: 56000 nM
Estimate against measurement, compound 4: 1.5-fold (0.18 log units) above, within the range that was stated.
By their numbers in this assay, from the lowest: compounds 3, 1 and 4 (each within the scatter of the next). At a limit, above all of these: compound 2.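

Replacing the whole sulfonamide-bearing group on this aromatic carbon of the five-membered ring with a silicon-containing group of 4 heavy atoms, which has no ring and no hydrogen-bond donors or acceptors, leaves this assay with no change that can be told from scatter: the steps are a 1.4-fold higher number from compound 3 to compound 4 (0.13 log units; within the scatter) and a 1.2-fold higher number from compound 1 to compound 4 (0.09 log units; within the scatter). The earlier compounds shown here could suggest that the sulfonamide-bearing group set compounds 1 and 3 apart from compound 2, but compound 4 lacks that group and still cannot be told apart from either, so at this level of activity neither that group's aromatic ring nor its hydrogen-bond donor is needed. The remaining comparison, an at least 1.7-fold lower number from compound 2 to compound 4 (0.25 log units; that floor lies within the scatter), rests on a limit, so it does not show that compound 4 truly parts from compound 2: the limit of > 100000 nM in this assay, at which 1 of the 4 values shown sits.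

As far as these compounds go, it remains open whether any group at this carbon can move the number well beyond the scatter, for instance a primary amine, a carboxylic acid or a longer alkyl chain. It is also unclear whether the silicon atom matters at all, since a tert-butyl group, its all-carbon counterpart, does not appear among these compounds.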